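The source may hold more compounds than are shown below. What is called first, only, known or untested is meant among the compounds shown, and "the series" means these compounds.

Compound 1 `Oc1cccc(/C=N/c2ccc(OCc3ccccc3)cc2)c1O` is the only entry with an actual number in a functional assay, with a stated time of 30 min; a lower number here means a stronger inhibitor, a higher number a weaker inhibitor; compound 1 gives 13300 nM there. Compound 2 `Oc1ccccc1/C=N/c1ccc(OCc2ccccc2)cc1` reaches only a limit in this assay, reported as > 200000 nM. That step is an at least 15-fold higher number from compound 1 to compound 2 (1.17 log units; beyond the scatter), the result sitting at the limit of > 200000 nM in this assay, at which 1 of the 2 values shown sits. Compound 3 `Cc1ccc(O)c(/C=N/c2ccc(OCc3ccccc3)cc2)c1` carries 2-hydroxy-5-methylphenyl in place of 2,3-dihydroxyphenyl on a carbon with a double bond to nitrogen. Removal of the second hydroxy is shared with the step from compound 1 to compound 2, so a similarly large weakening in this assay is expected, quite possibly ending at the limit again. Compound 3 is therefore estimated at 150000 nM, in the range 40000 nM to 400000 nM. The expected step is an 11-fold higher number from compound 1 to compound 3 (1.05 log units; beyond the scatter).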

Compound 3, half-maximal inhibitory concentration: > 200000 nM
Compound 3: a limit, no number (the forecaster's own chance of this, stated with the estimate: 55%); middle value at least 1.3-fold (0.12 log units) from the limit.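

In this assay, 2-hydroxy-5-methylphenyl in place of 2,3-dihydroxyphenyl gives an at least 15-fold higher number from compound 1 to compound 3 (1.17 log units; beyond the scatter), and this result is a limit, not a number. Compound 2 and compound 3 both lack the second hydroxy, so the loss now holds for two different groups at this position, and the methyl of compound 3 does not lift the result off the limit: the limit of > 200000 nM in this assay, at which 2 of the 3 values shown sit. The step from compound 2 to compound 3 cannot be read, as both results are limits.

From the compounds shown here alone, the true size of the loss, and any effect of the methyl alone, stay open. Also open, going by these compounds, is whether an amine or a carboxylic acid in place of the second hydroxy would keep a measurable number.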